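The source may report more compounds than this note shows. Statements on the series, on what has been measured and on what is new or still open speak of the compounds shown alone.

Of the compounds shown here, three built on one shared core have been tested in an ADME assay on HEK293 cells (Homo sapiens) for cytotoxicity, read by MTT assay, with a stated time of 36 h (a lower number here means a stronger inhibitor, a higher number a weaker inhibitor), so far. Compound 1 `O=C(c1ccc2c(c1)OCCO2)C1CCN(Cc2coc(-c3ccc(Cl)cc3)n2)CC1` gives > 150 ug/mL there, which is a limit of the assay rather than a number. Compound 2 `O=C(c1ccc2c(c1)OCCO2)C1CCN(Cc2coc(-c3cccc(F)c3)n2)CC1` likewise gives > 150 ug/mL as a limit. Compound 3 `O=C(c1ccc2c(c1)CCCC2)C1CCN(Cc2coc(-c3ccc(F)cc3)n2)CC1` gives > 150 ug/mL as a limit too. Among the measured compounds shown here, the single one-place step that has been measured, a step that the two limits leave unreadable from compound 1 to compound 2, cannot be read in size because both of its ends are limits. Compound 3 thus stands where the other two stand, all three sitting at the limit of > 150 ug/mL in this assay, at which 3 of the 3 values shown sit, in this assay.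

Compound 4 `COc1ccc(C(=O)C2CCN(Cc3coc(-c4ccc(F)cc4)n3)CC2)cc1OC` differs from compound 3 in one place: 3,4-dimethoxyphenyl in place of 1,2,3,4-tetrahydronaphthalen-6-yl on a carbonyl carbon. For the measured compounds named here, no measured step concerns a change at a carbonyl carbon, and the one step that was measured could not be read, so no size can be taken from the data for this change. Because compound 3 sits at the limit of > 150 ug/mL in this assay, at which 3 of the 3 values shown sit, the step that the limit leaves unreadable from compound 3 to compound 4 is expected to be none that this assay could show. Compound 4 is therefore estimated at 200 ug/mL, within a range of 120 ug/mL to 400 ug/mL, and is most likely to come back again as a limit rather than a number.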

Compound 4, half-maximal inhibitory concentration: > 150 ug/mL
Compound 4 was reported as a limit; the forecaster's own chance of this, stated with the estimate: 85%; the middle value is on the limit's open side.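

Compound 3 and compound 4 each give a limit of the assay rather than a number, so the step between them cannot be read: the limit of > 150 ug/mL in this assay, at which 4 of the 4 values shown sit.

The compounds shown leave open which change to the shared core, if any, would give a readable number in this assay.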